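Dropping a pyrazole chloro in a kinase inhibitor series

The source may hold more compounds than are shown below. What is called first, only, known or untested is meant among the compounds shown, and "the series" means these compounds.

Of the compounds shown here, three have so far been measured in an assay on isolated protein for inhibition of Leucine-rich repeat serine/threonine-protein kinase 2 variant G2019S (Homo sapiens), read by TR-FRET and LanthaScreen, with stated times of 50 min and 30 min, in the presence of a further agent that is not named here; a higher number here means a weaker inhibitor, a lower number a stronger inhibitor. Compound 1 `Cc1nn(CC2(O)COC2)cc1Nc1nc(N)c2c(C#N)c(N3CCC[C@H]3C)n(C)c2n1` gives 51 nM in this assay. Compound 2 `Cc1c(Nc2nc(N)c3c(C#N)c(N4CCC[C@H]4C)n(C)c3n2)cnn1[C@@H]1CCOC1` gives 12 nM in this assay. Compound 3 `C[C@@H]1CCCN1c1c(C#N)c2c(N)nc(Nc3cn(C)nc3Cl)nc2n1C` gives 21 nM in this assay. Among the three numbers compound 3 stands second highest: its nearest neighbour is compound 2, whose number lies within the usual scatter of that of compound 3, and the furthest is compound 1, whose number is higher than that of compound 3 by more than the scatter.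

Compound 4 `C[C@@H]1CCCN1c1c(C#N)c2c(N)nc(Nc3cnn(C)c3)nc2n1C` has not yet been measured in this assay. It differs from compound 3 in a single place: hydrogen in place of chloro on an aromatic carbon. Within the data shown here, no pair of measured compounds differs in only one place, so there is no measured step of this kind to guide the expectation. On the numbers available, the loss of the chloro group is expected to give compound 4 a somewhat higher number than compound 3, a step of about a 1.9-fold higher number from compound 3 to compound 4 (0.28 log units; within the scatter), small enough that it could still fall within the scatter. Compound 4 is therefore estimated at 40 nM in this assay, with a likely range from 15 nM to 110 nM.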

Compound 4, half-maximal inhibitory concentration: 5 nM
Compound 4: the middle estimate sits 8.0-fold (0.90 log units) above what was measured; measured number outside the range, below it.
By their numbers in this assay, from the lowest: compound 4; then compounds 2 and 3 (each within the scatter of the next); then compound 1.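

Replacing the chloro of the 3-chloro-1-methyl-1H-pyrazol-4-yl group with hydrogen gives a 4.2-fold lower number from compound 3 to compound 4 (0.62 log units; beyond the scatter) in this assay, so on this aromatic carbon, next to the ring nitrogen, the chloro group is not needed for a low number, and the compound with hydrogen there has the lower number by more than the scatter. This is the only step shown that changes a single place, whereas compounds 1, 2 and 3 differ from one another in more than one place and could not isolate the contribution of this position. Nothing measured on these compounds bears on the reason for the step, which therefore stays unexplained.

Among these compounds, whether any substituent here can match hydrogen remains open, since the position has been seen only with chloro and hydrogen, and a fluoro, methyl, methoxy or nitrile group at the same carbon could fall on either side of the two. As far as these compounds go, it is also open whether the same replacement would give a step of similar size alongside the larger groups on the ring nitrogen that compounds 1 and 2 carry.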